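Aryl swap on the core: clearance outlook for compound 3

This account rests on a few compounds, and the source may have more. Where it says the series, first, only, none or still open, it means among the compounds named here.

compound 1, `Cc1cc2oc(N3CCC(C(=O)N[C@H]4CCC[C@H](CO)C4)CC3)nc2cc1Cl`: 28.3 mL/min/kg
compound 2, `CCOc1ccc(-c2cc3oc(N4CCC(C(=O)N[C@H]5CCC[C@H](CO)C5)CC4)nc3cc2Cl)cc1`: < 8 mL/min/kg

In an ADME assay on microsomes from liver (Homo sapiens) for metabolic stability (a higher number here means faster removal of the compound, a lower number slower removal), compound 1 gives 28.3 mL/min/kg. Compound 2 reaches only a limit of the assay, < 8 mL/min/kg, so where it stands is known only as a bound. The change from compound 1 to compound 2 gave an at least 3.5-fold lower number from compound 1 to compound 2 (0.54 log units; beyond the scatter), and the limit of < 8 mL/min/kg in this assay, at which 1 of the 2 values shown sits, marks the end at which compound 2 sits.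

Compound 3, `O=C(N[C@H]1CCC[C@H](CO)C1)C1CCN(c2nc3cc(Cl)c(-c4cccc(Cl)c4)cc3o2)CC1`, is not yet measured in this assay. It differs from compound 2 by 3-chlorophenyl in place of 4-ethoxyphenyl on an aromatic carbon. Among the compounds with values here, one measured step bears on it: compound 1 to compound 2 showed an at least 3.5-fold lower number from compound 1 to compound 2 (0.54 log units; beyond the scatter), so the aryl-bearing compound 2 sits at the bound. Compound 3 keeps an aromatic ring at the same place, so only a small step is expected, an at least 1.2-fold higher number from compound 2 to compound 3 (0.09 log units; that floor lies within the scatter), its size left open by the bound on compound 2. For compound 3 the expected value in this assay is 10 mL/min/kg, between 5 mL/min/kg and 25 mL/min/kg, with a fair chance that only a limit is again reported.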

Compound 3, clearance: 55.8 mL/min/kg
The estimate for compound 3 lay 5.6-fold (0.75 log units) below the measured number; the whole stated range lies below it.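

In this assay, an aromatic ring at this carbon does not by itself hold the number down: replacing 4-ethoxyphenyl with 3-chlorophenyl gave an at least 6.9-fold higher number from compound 2 to compound 3 (0.84 log units; beyond the scatter). The low value of compound 2 therefore depends on the particular aryl group, since 3-chlorophenyl in place of methyl gave a 2.0-fold higher number from compound 1 to compound 3 (0.29 log units; within the scatter), leaving compound 3 and compound 1 unresolved in this assay. Compound 2 stands at a limit, so the step to compound 3 has a floor and no upper end: the limit of < 8 mL/min/kg in this assay, at which 1 of the 3 values shown sits.

The ring substituent and its place on the ring change together between compound 2 and compound 3, so the compounds shown cannot say which of the two matters. A 4-chlorophenyl or a 3-ethoxyphenyl group on this carbon would separate them, and an unsubstituted phenyl would show what the bare ring gives.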